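A few compounds are considered here, and "the series" means these few. Any claim that something is new, unique, unknown or untested is made for them only; others in the source may bear on it.

Measured in an assay on CHO cells for antagonist activity at transient receptor potential cation channel subfamily V member 1 (Homo sapiens), read by FLIPR; on this read-out higher numbers stand for weaker inhibition and lower numbers for stronger inhibition:
compound 1 `CC(C(=O)NCc1ccc(C(F)(F)F)nc1-c1ccc(N(C)C)cc1)c1ccc(NS(C)(=O)=O)c(F)c1` — 3.2 nM
compound 2 `CC(C(=O)NCc1ccc(C(F)(F)F)nc1CCc1ccccc1)c1ccc(NS(C)(=O)=O)c(F)c1` — 1.4 nM

Among the measured compounds shown here, compound 2 gives the lowest of the two numbers in this assay; the single measured step, a 2.3-fold lower number from compound 1 to compound 2 (0.36 log units; beyond the scatter), separates it from compound 1.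

Compound 3 `CC(C(=O)NCc1ccc(C(F)(F)F)nc1CCc1ccc(F)cc1)c1ccc(NS(C)(=O)=O)c(F)c1` differs from compound 2 by fluoro in place of hydrogen on an aromatic carbon. For the measured compounds named here, no measured step covers such a change; the only step, from compound 1 to compound 2, exchanges the whole group on that aromatic carbon and gives no guide for a fluoro in place of hydrogen. The expected step in this assay is therefore none beyond the scatter, a 1.1-fold lower number from compound 2 to compound 3 (0.03 log units; within the scatter).

Compound 3 is estimated at 1.3 nM, within 0.5 nM to 3.5 nM.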

Compound 3, inhibition constant: 1.8 nM
The estimate for compound 3 lay 1.4-fold (0.14 log units) below the measured number; the range from low to high includes it.
By their numbers in this assay, from the lowest: compounds 2, 3 and 1 (each within the scatter of the next, the first and the last beyond it).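

Read in this assay fluoro in place of hydrogen, para to a large group on the phenethyl ring, gives a step within the scatter (a 1.3-fold higher number from compound 2 to compound 3 (0.11 log units; within the scatter)), so this position accepts fluoro without a separable difference. Against the 4-(dimethylamino)phenyl of compound 1, the 2-(4-fluorophenyl)ethyl group also stays within the scatter (a 1.8-fold lower number from compound 1 to compound 3 (0.25 log units; within the scatter)), whereas phenethyl stood beyond it. Nothing available explains these numbers.
Open, as far as these compounds go, is whether chloro or methoxy at this ring position, or a propyl linker in place of the ethyl chain, would stay at this level.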